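A few compounds are considered here, and "the series" means these few. Any claim that something is new, unique, unknown or untested is made for them only; others in the source may bear on it.

Series notes. Compound 1 `CC(C)CN1CCC(CNC(=O)c2cc(Cl)cc3c2ncn3C)CC1`, compound 2 `CCCCN1CCC(CNC(=O)c2ccc(N)c3[nH]cnc23)CC1` and compound 3 `CS(=O)(=O)NCCN1CCC(COC(=O)c2cccc3[nH]cnc23)CC1` have been measured in an assay on membranes from striatum for binding affinity to 5-hydroxytryptamine receptor 4 (Rattus norvegicus); a higher number here means a weaker inhibitor, a lower number a stronger inhibitor. Compound 1 gives 2.2 nM, compound 2 gives 115 nM and compound 3 gives 26.1 nM. Compound 3 therefore stands second highest of the three numbers: its nearest neighbour is compound 2, whose number is higher by a gap beyond the usual scatter, and the furthest is compound 1, whose number is lower by a gap also beyond the scatter. Compound 4 `CS(=O)(=O)NCCN1CCC(COC(=O)c2cc(Cl)cc3[nH]cnc23)CC1` has not yet been measured in this assay. It differs from compound 3 in one place: chloro in place of hydrogen on an aromatic carbon. Among the measured compounds shown here, no pair of measured compounds differs only in this way, so the size of the step is not fixed by the data. Among the measured compounds only compound 1 carries a chloro, and compound 1 gives 2.2 nM, the lowest number here, though it differs in several other places as well. On that basis a step to a lower number is expected, of a size a 3.7-fold lower number from compound 3 to compound 4 (0.57 log units; beyond the scatter), beyond the scatter. Compound 4 is estimated at 7 nM, within the range 2 nM to 25 nM.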

Compound 4, inhibition constant: 2.3 nM
Estimate against measurement, compound 4: 3.0-fold (0.48 log units) above; the measured number falls inside the stated range.
By their numbers in this assay, from the lowest: compounds 1 and 4 (each within the scatter of the next); then compound 3; then compound 2.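

The change of hydrogen to chloro on this aromatic carbon, meta to a large group and para to a fused ring, gives in this assay an 11-fold lower number from compound 3 to compound 4 (1.05 log units; beyond the scatter), a large step for a single heavy atom. Among the compounds shown here, no earlier pair differed only in this way, so this is the first direct reading of what a chloro does at this position, and it holds for the side chain and linking group shared by these two compounds. Nothing measured here accounts for the size of the step.

As far as these compounds go, whether fluoro, bromo, methyl or an amine on this same carbon would give a step of like size remains open. Also open, from the compounds shown here alone, is whether the chloro step carries over to an amide link or to a butyl chain on the ring nitrogen.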